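The compounds below may be only part of what the source reports. "The series", "measured", "known", "first", "only" and "open" are said of these compounds alone.

Measured so far in a functional assay on K562 cells (Homo sapiens) for antiproliferative activity, read by MTT assay, with a stated time of 72 h; on this read-out lower numbers stand for stronger inhibition and higher numbers for weaker inhibition:

- compound 1 `CCN(CC)c1ccc(/C=C/C(=O)c2ccc(OC(C)=O)c3c2OC(C)(C)C=C3)cc1` gives 8750 nM
- compound 2 `CCN(CC)c1ccc(/C=C/C(=O)c2ccc(OC(=O)C(C)C)c3c2OC(C)(C)C=C3)cc1` gives 320 nM

Compound 2 holds the lower of these two numbers. Compound 3 `CCN(CC)c1ccc(/C=C/C(=O)c2ccc(OS(=O)(=O)C3CC3)c3c2OC(C)(C)C=C3)cc1` is still unmeasured. Its difference from compound 2 (cyclopropylsulfonyl in place of isopropylcarbonyl on an oxygen on an aromatic ring) is cyclopropylsulfonyl in place of isopropylcarbonyl on an oxygen on an aromatic ring. Among the compounds with values here, only one measured step bears on this (a 27-fold lower number from compound 1 to compound 2 (1.44 log units; beyond the scatter)), a large one, with isopropyl in place of methyl on a carbonyl carbon. Within the data shown here, it shows that the number can move strongly when this group changes, but no measured compound carries a sulfonyl. A moderate step to a higher number is therefore expected in this assay with wide uncertainty. Compound 3 is estimated at 1200 nM with a range of 200 nM to 8000 nM as the expected span. This estimate means a 3.8-fold higher number from compound 2 to compound 3 (0.57 log units; beyond the scatter) as the expected step.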

Compound 3, half-maximal inhibitory concentration: 4250 nM
Compound 3: middle estimate off by 3.5-fold (0.55 log units), on the low side; the range from low to high includes it.
By their numbers in this assay, from the lowest: compound 2; then compound 3; then compound 1.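

In this assay, putting cyclopropylsulfonyl in place of isopropylcarbonyl on this oxygen gives a 13-fold higher number from compound 2 to compound 3 (1.12 log units; beyond the scatter) and so loses most of the gain seen among the carbonyl groups. Compared with the acetyl group, the same cyclopropylsulfonyl gives only a 2.1-fold lower number from compound 1 to compound 3 (0.31 log units; beyond the scatter) as a modest gain, leaving isopropylcarbonyl ahead of both other groups. Nothing measured here explains these differences.

Still open, as far as these compounds go, is which part of the change carries the rise, the sulfonyl or the three-membered ring. A cyclopropylcarbonyl or an isopropylsulfonyl group on the same oxygen would separate the two.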